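The compounds below may be only part of what the source reports. "The series", "measured", "known", "first", "only" and "open" are said of these compounds alone.

Compound 1 `Cc1ncc(-c2cc(NC(=O)c3ccc(OCc4ccccn4)cc3)c(C)cc2C)[nH]1` and compound 2 `Cc1csc(-c2cc(NC(=O)c3ccc(OCc4ccccn4)cc3)c(C)cc2C)n1` share one core and differ only in the five-membered ring carried on an aromatic carbon of that core. In a physicochemical assay for lipophilicity (a lower number here means a more polar compound, a higher number a more lipophilic compound), compound 1 gives 2.8. For compound 2 this assay reports a limit, > 3, and no number. The step of a number at least 0.20 log units higher from compound 1 to compound 2 (that floor lies within the scatter) is thus known only at its floor, which rests on (the limit of > 3 in this assay, at which 1 of the 2 values shown sits); where compound 2 truly stands above that floor is open.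

Compound 3 `Cc1cc(C)c(-c2c[nH]nc2C)cc1NC(=O)c1ccc(OCc2ccccn2)cc1` has not been measured yet. It carries 3-methyl-1H-pyrazol-4-yl in place of 4-methyl-1,3-thiazol-2-yl on an aromatic carbon. For the measured compounds named here, the only step measured at this position is the one from compound 1 to compound 2, in which a five-membered ring with 2 hetero atoms was exchanged for another and this assay rose by at least the floor given. Compound 3 exchanges the ring once more for a five-membered ring with 2 hetero atoms that, like the ring of compound 1, is of the azole type without sulfur. Compound 3 is therefore expected to fall back toward compound 1, a step estimated at a number at least 0.10 log units lower from compound 2 to compound 3 (that floor lies within the scatter). The estimate for compound 3 in this assay is 2.9, expected between 2.5 and 3.3.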

Compound 3, distribution coefficient: > 3
Compound 3 was reported as a limit; the forecaster's own chance of this, stated with the estimate: 25%; middle value at least 0.10 log units from the limit.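

In this assay compound 3 gives > 3, which is a limit of the assay and not a number. Setting 3-methyl-1H-pyrazol-4-yl in place of 2-methyl-1H-imidazol-5-yl gives a number at least 0.20 log units higher from compound 1 to compound 3 (that floor lies within the scatter), so a ring without sulfur, carrying 1 hydrogen-bond donor, reaches the same limit at this position as the 4-methyl-1,3-thiazol-2-yl of compound 2, whereas before only the thiazole had done so. The step between compound 2 and compound 3 cannot be read, and the two rings cannot be ranked against each other, since the values for this position now mostly end at the same limit: the limit of > 3 in this assay, at which 2 of the 3 values shown sit.

From the compounds shown here alone, how far compound 2 and compound 3 truly lie past that limit remains open, as does whether either differs from compound 1 by more than the scatter, since the floors of their steps lie within it. Also open, going by these compounds, is how this assay would respond at this position to a five-membered ring bearing an amine or a carboxylic acid, or to a longer chain in place of its methyl group.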